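The compounds below may be only part of what the source reports. "The series", "measured", "known", "first", "only" and "open" are said of these compounds alone.

Compound 3 `CCCCCCSc1nnc(COc2cc(C)c3c(C)cc(=O)oc3c2)o1` belongs to a small series of three analogues sharing one core. In a functional assay on MDA-MB-231 cells (Homo sapiens) for antiproliferative activity, read by MTT assay, with a stated time of 24 h (on this read-out higher numbers stand for weaker inhibition and lower numbers for stronger inhibition), compound 1 `CCSc1nnc(COc2cc(C)c3c(C)cc(=O)oc3c2)o1` reaches only the limit of the assay, > 100000 nM. Compound 2 `CCCCCSc1nnc(COc2cc(C)c3c(C)cc(=O)oc3c2)o1` likewise stops at the limit, giving > 100000 nM in this assay. Compound 3 too gives only the limit, > 100000 nM, in this assay. Where compound 3 stands among the numbers shown is thus only this: every value in the series sits at the limit of > 100000 nM in this assay, at which 3 of the 3 values shown sit. The steps a step that the two limits leave unreadable from compound 1 to compound 2, a step that the two limits leave unreadable from compound 1 to compound 3 and a step that the two limits leave unreadable from compound 2 to compound 3 are unreadable, since both ends of each are limits.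

Compound 4 `CCS(=O)(=O)c1nnc(COc2cc(C)c3c(C)cc(=O)oc3c2)o1` differs from compound 3 by ethylsulfonyl in place of hexylsulfanyl on an aromatic carbon. Within the data shown here, no measured step bears on this change, and the three steps offer neither a size nor a direction for this assay. The step from compound 3 to compound 4 is therefore expected to be a number no higher from compound 3 to compound 4 (the limit leaves the size open), with the assay most likely again reporting only a limit. Compound 4 is estimated at 100000 nM, within a range from 30000 nM to 300000 nM.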

Compound 4, half-maximal inhibitory concentration: > 100000 nM
Compound 4 was reported as a limit; the forecaster's own chance of this, stated with the estimate: 75%; the middle value sits exactly at the limit.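

In this assay, among these compounds, compound 4 gives > 100000 nM as a limit of the assay, so no step to it from compound 1, compound 2 or compound 3 can be read, and the series ends thus: the limit of > 100000 nM in this assay, at which 4 of the 4 values shown sit.

The compounds shown leave open whether any change on the shared core alters antiproliferative activity, in either direction or by any size.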